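The source may hold more compounds than are shown below. What is called first, only, known or untested is meant among the compounds shown, and "the series" means these compounds.

Compound 1 `CN(Cc1ccc(C(=O)O)cc1)c1ccc(OCc2c(-c3c(Cl)cccc3Cl)noc2C2CC2)nc1C(F)(F)F` and compound 2 `CN(Cc1ccc(C(=O)NCCS(=O)(=O)O)cc1)c1ccc(OCc2c(-c3c(Cl)cccc3Cl)noc2C2CC2)nc1C(F)(F)F` share a core and differ only at the carboxylic acid end. In an assay on isolated protein for agonist activity at Bile acid receptor (Homo sapiens), read by FRET (a higher number here means that more compound is needed for the effect, a lower number that less compound is needed), compound 1 gives 12 nM, and compound 2 gives 14 nM; the step of a 1.2-fold higher number from compound 1 to compound 2 (0.07 log units; within the scatter) shows that extending the acid end with a (2-sulfoethyl)amino group leaves the result essentially unchanged. For the measured compounds named here, compound 1 thus holds the lower of the two numbers known so far, though the gap to compound 2 lies within the scatter.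

Compound 3 `CC(Oc1ccc(C(=O)O)cc1)c1ccc(OCc2c(-c3c(Cl)cccc3Cl)noc2C2CC2)nc1C(F)(F)F` changes a different part of the molecule: 1-(4-carboxyphenoxy)ethyl in place of (4-carboxybenzyl)(methyl)amino on an aromatic carbon. Going by the values given here, no measured step touches this linker region, so the one step known, which concerns only the acid end, gives no direct guidance. With the carboxyphenyl group now attached through an oxygen and a branched carbon rather than through a methylated nitrogen, a moderate loss is expected, a 3.3-fold higher number from compound 1 to compound 3 (0.52 log units; beyond the scatter), with wide uncertainty. Compound 3 is therefore estimated at 40 nM in this assay, in a range from 8 nM to 300 nM.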

Compound 3, half-maximal effective concentration: 352 nM
The estimate for compound 3 lay 8.8-fold (0.94 log units) below the measured number; measured number outside the range, above it.
By their numbers in this assay, from the lowest: compounds 1 and 2 (each within the scatter of the next); then compound 3.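

In this assay the swap at this position gives a 29-fold higher number from compound 1 to compound 3 (1.47 log units; beyond the scatter) and so shows that, unlike the acid end, this part of the molecule does not accept every change. The two groups have the same number of heavy atoms, the same kind of carbon-only aromatic ring and the same counts of hydrogen-bond donors and acceptors, so matching these counts does not keep the number low. No measurement here points to a reason for the step.

The change replaces a methylated nitrogen with an oxygen and also brings in a branched carbon, and the compounds shown do not separate these two features. A (4-carboxyphenoxy)methyl group, without the extra methyl, would test the oxygen alone, while an ethyl in place of the methyl on the nitrogen would probe the other side.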